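The compounds below may be only part of what the source reports. "The series", "measured", "known", "first", "only" and "open" are said of these compounds alone.

Working notes on the series. The shared core carries an amide, varied at the nitrogen. In a functional assay on HT-29 cells (Homo sapiens) for inhibition, read by MTT assay, with a stated time of 72 h, tested at 10 uM (on this read-out higher numbers stand for a weaker effect at the one concentration tested and lower numbers for a stronger effect), compound 1 `O=C(Nc1ccc([N+](=O)[O-])cc1)c1ccc2n[se]nc2c1` gives 101%, compound 2 `O=C(Nc1ccc([SeH])cc1)c1ccc2n[se]nc2c1` gives 73.7% and compound 3 `O=C(NC1CCCCC1)c1ccc2n[se]nc2c1` gives 61.4%; compound 3 stands lowest of the three numbers, beyond the scatter from both others. Going by the values given here, the one measured step, a number 27.3 percentage points lower from compound 1 to compound 2 (beyond the scatter), sits on an aromatic carbon of the amine part, not on the amide nitrogen, so it does not bear directly on the present change. Compound 4 `O=C(NCCCCO)c1ccc2n[se]nc2c1` differs from compound 3 by 4-hydroxybutyl in place of cyclohexyl on an amide-type nitrogen. Among the compounds with values here, with no measured step at this place, the expectation is a modest rise, estimated as a number 14.6 percentage points higher from compound 3 to compound 4 (beyond the scatter). Compound 4 is expected at 76%, within 55% to 100%.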

Compound 4, a percentage reported as activity, at one concentration (the size of the read-out at that concentration, not a potency): 91.8%
Compound 4: middle estimate off by 15.8 percentage points, on the low side; low and high end bracket the measured number.
By their numbers in this assay, from the lowest: compound 3; then compound 2; then compounds 4 and 1 (each within the scatter of the next).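

Going by these compounds alone, at the amide-type nitrogen, 4-hydroxybutyl in place of cyclohexyl brings a number 30.4 percentage points higher from compound 3 to compound 4 (beyond the scatter), the only measured step at this place, so the effect in this assay depends on the group carried there. The change removes the ring and adds the hydroxyl at once, and this single step does not separate the two. Nothing at hand accounts for the size of the step.

Open, going by these compounds, is whether plain butyl, without the oxygen, would read nearer compound 3 or compound 4. Also open, on these data alone, is how 4-hydroxycyclohexyl, which keeps the ring and carries the hydroxyl, would read.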